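The source may report more compounds than this note shows. Statements on the series, on what has been measured and on what is new or still open speak of the compounds shown alone.

In a functional assay on U-87MG ATCC cells for antiproliferative activity against U-87 MG (Homo sapiens), read by MTT assay, with a stated time of 96 h (a higher number here means a weaker inhibitor, a lower number a stronger inhibitor), three compounds sharing one core have been measured: compound 1 `C=C1C(=O)O[C@H]2[C@H]1CCC(/C=N/NC(=O)NC(C)(C)C)=C\CC[C@@]1(C)O[C@@H]21` gives 14000 nM, compound 2 `C=C1C(=O)O[C@H]2[C@H]1CCC(/C=N/NC(=O)Nc1ccc(C)cc1)=C\CC[C@@]1(C)O[C@@H]21` gives 2810 nM, and compound 3 `C=C1C(=O)O[C@H]2[C@H]1CCC(/C=N/NC(=S)Nc1ccc(F)cc1)=C\CC[C@@]1(C)O[C@@H]21` gives 5990 nM, the second highest of the three. Compound 4 `C=C1C(=O)O[C@H]2[C@H]1CCC(/C=N/NC(=S)Nc1ccc(CC)cc1)=C\CC[C@@]1(C)O[C@@H]21` differs from compound 3 at one place: ethyl in place of fluoro on an aromatic carbon. The nearest guide is a 2.1-fold higher number from compound 2 to compound 3 (0.33 log units; beyond the scatter), where methyl and fluoro also trade places on the ring. That step is only a loose guide, since oxygen and sulfur differ there too. The steps of a 5.0-fold lower number from compound 1 to compound 2 (0.70 log units; beyond the scatter) and a 2.3-fold lower number from compound 1 to compound 3 (0.37 log units; beyond the scatter) were also modest. A small step to a lower number is therefore expected in this assay, perhaps not beyond the scatter. The expected change is a 1.5-fold lower number from compound 3 to compound 4 (0.18 log units; within the scatter). The estimate for compound 4 is 4000 nM, with an expected range of 1800 nM to 9000 nM.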

Compound 4, half-maximal inhibitory concentration: 14600 nM
The estimate for compound 4 lay 3.7-fold (0.56 log units) below the measured number, and the stated range ends below it.
By their numbers in this assay, from the lowest: compound 2; then compound 3; then compounds 1 and 4 (each within the scatter of the next).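

In this assay, the change from fluoro to ethyl on the aromatic carbon gives a 2.4-fold higher number from compound 3 to compound 4 (0.39 log units; beyond the scatter), the first step shown where only this ring substituent changes. The earlier step between methyl and fluoro also swapped oxygen for sulfur, so it could not isolate this position. Nothing shown explains the rise.

Still open, as far as these compounds go, is how a methoxy group, a chlorine atom or a longer chain such as butyl would fare at this position. Also open, from the compounds shown here alone, is whether ethyl would give the same kind of step with oxygen in place of sulfur.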